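A few compounds are considered here, and "the series" means these few. Any claim that something is new, unique, unknown or untested is made for them only; others in the source may bear on it.

Measured so far:
Compound 1 `c1coc(CNc2nc(NCCCN3CCCC3)nc3ccccc23)c1` gives 16100 nM in a functional assay on HCT-116 cells (Homo sapiens) for cytotoxicity, read by MTT assay, with a stated time of 2 days; a lower number here means a stronger inhibitor, a higher number a weaker inhibitor.
Compound 2 `Cc1cccc(N2CCN(CCCNc3nc(NCc4ccco4)c4cc(F)ccc4n3)CC2)c1C` gives 1140 nM in this assay.
Compound 3 `Clc1cccc(N2CCN(CCCNc3nc(NCc4ccco4)c4ccccc4n3)CC2)c1Cl` gives 3360 nM in this assay.

Compound 1 has the highest number of the three and so is the weakest inhibitor among them; compound 3 is nearest to it and compound 2 furthest, and both gaps lie beyond the scatter. Compound 4 `CCN(CC)CCNc1nc(NCc2ccco2)c2ccccc2n1` is not yet measured. It differs from compound 1 in one place: diethylamino in place of (pyrrolidin-1-yl)methyl on a saturated chain carbon, two bonds along the chain from a nitrogen on an aromatic ring. One amine-bearing chain end is exchanged for another, and the shared core is untouched. Among the measured compounds shown here, no measured pair shows such a swap, so the expectation rests on compound 1 alone. The expected step is a 1.2-fold higher number from compound 1 to compound 4 (0.09 log units; within the scatter), small and in no clear direction beyond the scatter. Compound 4 is therefore estimated at 20000 nM, with a range from 6000 nM to 60000 nM.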

Compound 4, half-maximal inhibitory concentration: 25900 nM
Beside the measured number, compound 4's estimate is 1.3-fold (0.11 log units) below it; measured number inside the range.
By their numbers in this assay, from the lowest: compound 2; then compound 3; then compounds 1 and 4 (each within the scatter of the next).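

In this assay, exchanging the 3-(pyrrolidin-1-yl)propyl end for 2-(diethylamino)ethyl gives a 1.6-fold higher number from compound 1 to compound 4 (0.21 log units; within the scatter) and so leaves these two amine-bearing ends indistinguishable here. This first direct pair shows that losing the ring and shortening the chain together need not move the number beyond the scatter. No available data explain this result. From the compounds shown here alone, whether the ring or the chain length would matter alone stays open, since they change together here. A 3-(diethylamino)propyl or 3-morpholinopropyl end could separate or extend this picture.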